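This account rests on a few compounds, and the source may have more. Where it says the series, first, only, none or still open, it means among the compounds named here.

Compound 3 `COc1ccc(Cl)cc1S(=O)(=O)Nc1ccc(-c2nc3ccccc3o2)cc1` is one of three closely related sulfonamides tested in an assay on isolated protein for inhibition of malate dehydrogenase, mitochondrial (Sus scrofa), with stated times of 45 min and 30 min; a higher number here means a weaker inhibitor, a lower number a stronger inhibitor. In this assay compound 3 gives > 63000 nM, which is a limit of the assay and not a number. Its companion compound 1 `O=S(=O)(Nc1ccc(-c2nc3ccccc3o2)cc1)c1cccc(Cl)c1` gives > 63000 nM in this assay, again a limit. Compound 2 `O=S(=O)(Nc1ccc(-c2nc3ccccc3o2)cc1)c1ccccc1O` likewise gives > 63000 nM in this assay, also a limit. Because of the limit of > 63000 nM in this assay, at which 3 of the 3 values shown sit, none of the steps among them can be read: a step that the two limits leave unreadable from compound 1 to compound 2, a step that the two limits leave unreadable from compound 1 to compound 3 and a step that the two limits leave unreadable from compound 2 to compound 3 all remain of unreadable size.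

Compound 4 `Cc1cccc(S(=O)(=O)Nc2ccc(-c3nc4ccccc4o3)cc2)c1` is not yet measured. It differs from compound 3 in one place: 3-methylphenyl in place of 5-chloro-2-methoxyphenyl on a sulfonyl sulfur. All three measured steps bear on it only as limits, so no direction can be drawn from them, and nothing in the data suggests that this change would bring the value within the readable range. For compound 4 the expectation is therefore a further limit, with a step that the limit leaves unreadable from compound 3 to compound 4 expected to be unreadable, and an estimated 90000 nM spanning 30000 nM to 300000 nM.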

Compound 4, half-maximal inhibitory concentration: > 63000 nM
Compound 4: a limit, no number; the forecaster's own chance of this, stated with the estimate: 85%; the middle value lies beyond the limit too.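

No new step can be read between compound 4 and compound 1, compound 2 or compound 3, because each value is a limit and not a number: the limit of > 63000 nM in this assay, at which 4 of the 4 values shown sit. The compounds shown leave open which group on the sulfonyl sulfur, if any, would give a readable value in this assay.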